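This account rests on a few compounds, and the source may have more. Where it says the series, first, only, none or still open, it means among the compounds named here.

Series notes. Among the compounds with values here, in an assay for inhibition of gamma-butyrobetaine dioxygenase (Homo sapiens), read by HPLC, with stated times of 15 min and 30 min (on this read-out lower numbers stand for stronger inhibition and higher numbers for weaker inhibition), compound 3 (`CC(C)[N+](C)(C)CCCC(=O)[O-]`) gives 5700 nM and is the only member with a number rather than a limit. Compound 1 (`CCCC[N+](C)(C)CCCC(=O)[O-]`) gives > 1000000 nM in this assay, which is a limit of the assay. Compound 2 (`CCC[N+](C)(C)CCCC(=O)[O-]`) gives > 1000000 nM in this assay, also a limit. The next member is compound 4 (`C#CC[N+](C)(C)CCCC(=O)[O-]`), which differs from compound 3 by propargyl in place of isopropyl on an amine nitrogen.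

Within the data shown here, two measured steps touch the same nitrogen. The step of an at least 170-fold lower number from compound 1 to compound 3 (2.24 log units; beyond the scatter) and the step of an at least 170-fold lower number from compound 2 to compound 3 (2.24 log units; beyond the scatter) both read as the branched isopropyl giving a lower number than an unbranched butyl or propyl, though both rest on the limit of > 1000000 nM in this assay, at which 2 of the 3 values shown sit, so their full size is not known. The step that the two limits leave unreadable from compound 1 to compound 2 gives no readable information. Compound 4 carries an unbranched group again, propargyl, which like propyl lacks branching but carries a triple bond that neither compound 1 nor compound 2 has. The expectation is therefore a move back toward higher numbers in this assay, of uncertain size, with a real chance that only a limit is returned. The expected step is an 11-fold higher number from compound 3 to compound 4 (1.02 log units; beyond the scatter). Compound 4 is estimated at 60000 nM, with a range from 8000 nM to 1000000 nM.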

Compound 4, half-maximal inhibitory concentration: 1400 nM
Compound 4: middle estimate off by 43-fold (1.63 log units), on the high side; the whole stated range lies above it.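

The step of a 4.1-fold lower number from compound 3 to compound 4 (0.61 log units; beyond the scatter) in this assay shows that, on this amine nitrogen, an unbranched group can give a lower number than the branched isopropyl, so compound 4 goes against the reading that branching alone orders the series. The triple bond separates compound 4 from the saturated unbranched groups far more clearly, with an at least 710-fold lower number from compound 2 to compound 4 (2.85 log units; beyond the scatter) and an at least 710-fold lower number from compound 1 to compound 4 (2.85 log units; beyond the scatter), so the unbranched groups shown do not behave as one class at this position. The full size of these two steps remains unknown, as compound 1 and compound 2 each give only a limit of the assay: the limit of > 1000000 nM in this assay, at which 2 of the 4 values shown sit.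

The compounds shown leave open whether the lower number of compound 4 needs the triple bond itself or its terminal position, a question that allyl, with a double bond, or but-2-ynyl, with an internal triple bond, on the same nitrogen would address. They also leave open whether a ring such as cyclopropyl, which combines a branched attachment with no triple bond, would follow isopropyl or propargyl in this read-out.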